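From phenyl to 3,5-difluorophenyl: the step to compound 4

The compounds below may be only part of what the source reports. "The series", "measured", "known", "first", "only" and "open" are said of these compounds alone.

Measured in a functional assay on MCF7 cells (Homo sapiens) for antiproliferative activity, read by sulforhodamine B assay, with a stated time of 48 h; a lower number here means a stronger inhibitor, a higher number a weaker inhibitor:
Compound 1 `CCCN1CCN(c2ccc(S(=O)(=O)Oc3ccc(C)cc3C)cc2)C1=O`: 1500 nM
Compound 2 `CCCN1CCN(c2ccc(S(=O)(=O)Oc3cccc(Cl)c3)cc2)C1=O`: 380 nM
Compound 3 `CCCCN1CCN(c2ccc(S(=O)(=O)Oc3ccccc3)cc2)C1=O`: 8800 nM

Compound 3 has the highest number of the three, and its gaps to compound 1 and compound 2 both lie beyond the scatter. Compound 4 `CCCCN1CCN(c2ccc(S(=O)(=O)Oc3cc(F)cc(F)c3)cc2)C1=O` differs from compound 3 in one place. It carries 3,5-difluorophenyl in place of phenyl on an oxygen. Among the measured compounds shown here, only one measured step changes the group at this place, a 3.9-fold lower number from compound 1 to compound 2 (0.60 log units; beyond the scatter). That step is modest, beyond the scatter, and was measured on propyl rather than butyl compounds. For the measured compounds named here, no measured pair starts from phenyl or carries fluorine, so a step of similar modest size towards a lower number in this assay is only a tentative expectation. The expected step is a 4.0-fold lower number from compound 3 to compound 4 (0.60 log units; beyond the scatter). For compound 4 the estimated value is 2200 nM, with an expected range of 600 nM to 6000 nM.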

Compound 4, half-maximal inhibitory concentration: 400 nM
Beside the measured number, compound 4's estimate is 5.5-fold (0.74 log units) above it, outside the stated range (below it).
By their numbers in this assay, from the lowest: compounds 2 and 4 (each within the scatter of the next); then compound 1; then compound 3.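

In this assay, 3,5-difluorophenyl in place of phenyl on an oxygen gives a 22-fold lower number from compound 3 to compound 4 (1.34 log units; beyond the scatter) in the butyl series. Among the compounds shown here, this shows that a change at this place can produce a large step, whereas the only earlier step here, measured on propyl compounds, was the modest 3.9-fold lower number from compound 1 to compound 2 (0.60 log units; beyond the scatter). Nothing available explains the size of this step.

On these data alone, it remains open whether 3,5-difluorophenyl would give as large a step on a propyl compound, and whether a single fluorine would do the same. As far as these compounds go, how a pyridine ring in place of phenyl would read in this assay is also open.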